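Fluoro to trifluoromethyl on two related cores

The compounds below may be only part of what the source reports. "The series", "measured", "known", "first", "only" and "open" are said of these compounds alone.

Compound 1 `C=C1C(=O)[C@]23C[C@@]1(O)CC[C@H]2c1ccc(O)c(C)c1[C@@H]3Cn1cc(-c2ccc(F)cc2)nn1` and compound 2 `C=C1C(=O)[C@]23C[C@@]1(O)CC[C@H]2c1ccc(O)c(C)c1[C@@H]3Cn1cc(-c2ccc(C(F)(F)F)cc2)nn1` share one core; compound 3 `C=C1C[C@]23C[C@@]1(O)CC[C@@H]2c1cccc(C)c1[C@@H]3Cn1cc(-c2ccc(F)cc2)nn1` and compound 4 `C=C1C[C@]23C[C@@]1(O)CC[C@@H]2c1cccc(C)c1[C@@H]3Cn1cc(-c2ccc(C(F)(F)F)cc2)nn1` share another. The difference between the two cores is not broken down here. In a functional assay on MCF7 cells (Homo sapiens) for cytotoxicity, read by MTT assay, with a stated time of 4 days (a lower number here means a stronger inhibitor, a higher number a weaker inhibitor), compound 1 gives 1700 nM and compound 2 gives 1840 nM. The change between them is trifluoromethyl in place of fluoro on an aromatic carbon, and it made a 1.1-fold higher number from compound 1 to compound 2 (0.03 log units; within the scatter). Compound 3 reaches only a limit in this assay, > 20000 nM, which is the limit of > 20000 nM in this assay, at which 1 of the 3 values shown sits. The change from compound 3 to compound 4 is the same one, (trifluoromethyl in place of fluoro on an aromatic carbon). Because a 1.1-fold higher number from compound 1 to compound 2 (0.03 log units; within the scatter) held within the scatter, compound 4 is expected to read 25000 nM, between 10000 nM and 60000 nM, most likely again reported only as a limit. The expected step is a step that the limit leaves unreadable from compound 3 to compound 4.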

Compound 4, half-maximal inhibitory concentration: > 20000 nM
Compound 4 gave a limit, no number; the forecaster's own chance of this, stated with the estimate: 85%; the middle value lies beyond the limit too.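

Compound 3 and compound 4 both stand only at a limit in this assay, so no step between them can be read: the limit of > 20000 nM in this assay, at which 2 of the 4 values shown sit.

The compounds shown leave open whether trifluoromethyl in place of fluoro changes the reading at all on the core of compound 3.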